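Capping the Acid of Compound 2 with an Isopropyl Ester

The compounds below may be only part of what the source reports. "The series", "measured", "known", "first", "only" and "open" are said of these compounds alone.

Compound 1, `Cc1cc(C(=O)N2CCCCc3ccccc32)ccc1CNC(=O)NCC(=O)N1CCCCC1`, gives 150 nM in a functional assay on HEK293 cells for agonist activity at Vasopressin V2 receptor (Homo sapiens), read by a luciferase reporter and cAMP accumulation; a higher number here means that more compound is needed for the effect, a lower number that less compound is needed.
Compound 2, `Cc1cc(C(=O)N2CCCCc3ccccc32)ccc1CNC(=O)N1CCC[C@H]1C(=O)O`, gives 680 nM in this assay.

Two compounds share one core and differ only in the group on the urea carbonyl carbon. Among the measured compounds shown here, the step of a 4.5-fold higher number from compound 1 to compound 2 (0.66 log units; beyond the scatter) is the only measured step, and compound 2 stands at the highest of the two numbers, with compound 1 as its nearest neighbour. Compound 3, `Cc1cc(C(=O)N2CCCCc3ccccc32)ccc1CNC(=O)N1CCC[C@H]1C(=O)OC(C)C`, keeps the 2-carboxypyrrolidin-1-yl of compound 2 but changes its end: isopropyl in place of hydrogen on an oxygen next to a carbonyl group, so that carboxy becomes isopropoxycarbonyl.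

For the measured compounds named here, no measured step covers this exact change. Going by the values given here, the one step that bears on it is indirect: going from the neutral piperidine amide of compound 1 to the free acid of compound 2 raised the number, so replacing the acid hydrogen with isopropyl may move the number back toward that of compound 1, though the pyrrolidine ring of compound 2 stays in place. A modest fall is therefore expected, a 2.3-fold lower number from compound 2 to compound 3 (0.36 log units; beyond the scatter), with wide uncertainty. Compound 3 is estimated at 300 nM, between 100 nM and 1000 nM.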

Compound 3, half-maximal effective concentration: 950 nM
Estimate against measurement, compound 3: 3.2-fold (0.50 log units) below; measured number inside the range.
By their numbers in this assay, from the lowest: compound 1; then compounds 2 and 3 (each within the scatter of the next).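

In this assay the change from carboxy to isopropoxycarbonyl gives no reading that can be separated from the free acid (a 1.4-fold higher number from compound 2 to compound 3 (0.15 log units; within the scatter)), so at this end of the 2-carboxypyrrolidin-1-yl group, the hydrogen and the isopropyl cannot be told apart in this assay. The ester also stays well away from the neutral piperidine amide (a 6.3-fold higher number from compound 1 to compound 3 (0.80 log units; beyond the scatter)), a gap of the same kind as the one already seen for the acid (a 4.5-fold higher number from compound 1 to compound 2 (0.66 log units; beyond the scatter)), so capping the acid does not close the distance to compound 1, and the free acid alone cannot account for that distance. No measured information shown here explains why the two end groups read alike.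

The compounds shown leave open whether the gap to compound 1 follows the pyrrolidine ring or the group attached to it, which a pyrrolidine carrying a piperidine amide at the same place would help to separate. They also leave open whether a methyl ester, a primary amide or a longer chain at this end would read differently from the acid and the isopropyl ester.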